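Ester tail variants of the shared core: compound 3

The source may report more compounds than this note shows. Statements on the series, on what has been measured and on what is new or still open speak of the compounds shown alone.

The shared core is that of compound 1 `C/C=C1/[C@H](O[C@@H]2O[C@H](CO)[C@@H](O)[C@H](O)[C@H]2O)OC=C(C(=O)O)[C@H]1CC(=O)OC`, which in a functional assay on SK-BR-3 cells (Homo sapiens) for antiproliferative activity, read by MTT assay, with a stated time of 72 h (a higher number here means a weaker inhibitor, a lower number a stronger inhibitor), reaches only the assay limit, > 20000 nM. Compound 2 `C/C=C1/[C@H](O[C@@H]2O[C@H](CO)[C@@H](O)[C@H](O)[C@H]2O)OC=C(C(=O)OC)[C@H]1CC(=O)OCCc1ccc2c(c1)OCCO2` carries a longer ester tail on the same core. In this assay compound 2 likewise gives only a limit, > 20000 nM. Both values shown sit at the same limit (the limit of > 20000 nM in this assay, at which 2 of the 2 values shown sit), so compound 2 stands at the top of the range and cannot be ordered against compound 1.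

Compound 3 `C/C=C1/[C@H](O[C@@H]2O[C@H](CO)[C@@H](O)[C@H](O)[C@H]2O)OC=C(C(=O)OC)[C@H]1CC(=O)OCCc1ccc(OC)c(OC)c1` differs from compound 2 by 3,4-dimethoxyphenyl in place of 2,3-dihydro-1,4-benzodioxin-6-yl on a saturated chain carbon, two bonds along the chain from an oxygen next to a carbonyl group. No step between measured compounds covers this change, and the two limits shown give no direction for it. The step that the limit leaves unreadable from compound 2 to compound 3 is therefore expected to be none beyond the scatter. Compound 3 is expected to give about 30000 nM in this assay, within 10000 nM to 100000 nM, most probably reported again as a limit rather than a number.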

Compound 3, half-maximal inhibitory concentration: > 15000 nM
Compound 3 gave a limit, no number; the forecaster's own chance of this, stated with the estimate: 80%; the middle value lies beyond the limit too.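

In this assay compound 3 gives only a limit, > 15000 nM. Compound 2 also gives only a limit, > 20000 nM. For the compounds shown here, no step between compound 2 and compound 3 can be read from these two limits. The compounds shown leave open how these ester tails on the shared core rank in this assay.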